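The source may report more compounds than this note shows. Statements on the series, on what has been measured and on what is new or still open speak of the compounds shown alone.

Measured compounds:
- compound 1 `Nc1ccccc1NC(=O)c1ccc(CSC(=S)N2CCN(Cc3ccccn3)CC2)cc1`: 61.4%
- compound 2 `Nc1ccccc1NC(=O)c1ccc(CSC(=S)N2CCN(Cc3ccccc3)CC2)cc1`: 31.3%
- compound 3 `Nc1ccccc1NC(=O)c1ccc(CSC(=S)N2CCN(c3cnccn3)CC2)cc1`: 76.9%

All three share one core and differ only in the group carried by the ring nitrogen. In a functional assay on HeLa cells (Homo sapiens) for antiproliferative activity, read by CCK-8 assay, with a stated time of 72 h, tested at 8 uM (on this read-out lower numbers stand for a weaker effect and higher numbers for a stronger effect at the one concentration tested), compound 3 stands highest of the three, with compound 1 the nearest and compound 2 the furthest behind. The steps already seen point one way: a change of a number 30.1 percentage points lower from compound 1 to compound 2 (beyond the scatter), and a change of a number 45.6 percentage points higher from compound 2 to compound 3 (beyond the scatter), while the smaller change of a number 15.5 percentage points higher from compound 1 to compound 3 (beyond the scatter) completes the picture.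

Compound 4 `Nc1ccccc1NC(=O)c1ccc(CSC(=S)N2CCN(c3ccccc3)CC2)cc1` is not yet measured. It differs from compound 3 as follows: phenyl in place of pyrazin-2-yl on an amine nitrogen in a ring. This is the same kind of exchange, a ring with two nitrogens giving way to a ring of carbon only, that occurs from compound 1 to compound 2 on a chain carbon rather than directly on the ring nitrogen; there it cost a large part of the effect. The step from compound 2 to compound 3 bears on it too, since compound 4 keeps the direct attachment of compound 3 but takes the all-carbon ring of compound 2. A large fall is therefore expected, of about a number 31.9 percentage points lower from compound 3 to compound 4 (beyond the scatter), so that compound 4 is estimated at 45%, within 25% to 65%.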

Compound 4, a percentage reported as inhibition, at one concentration (the size of the read-out at that concentration, not a potency): 73.1%
Beside the measured number, compound 4's estimate is 28.1 percentage points below it, outside the stated range (above it).
By their numbers in this assay, from the lowest: compound 2; then compound 1; then compounds 4 and 3 (each within the scatter of the next).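

In this assay, the exchange of pyrazin-2-yl for phenyl on the ring nitrogen gives a number 3.8 percentage points lower from compound 3 to compound 4 (within the scatter), so the hetero atoms of pyrazin-2-yl are not needed at this position to keep the effect at the one concentration tested. The link to the ring matters more here: setting phenyl directly on the ring nitrogen in place of benzyl gives a number 41.8 percentage points higher from compound 2 to compound 4 (beyond the scatter), and setting it there in place of (pyridin-2-yl)methyl gives a number 11.7 percentage points higher from compound 1 to compound 4 (beyond the scatter). Going by these compounds alone, the all-carbon ring therefore carries no general penalty, since the loss seen as a number 30.1 percentage points lower from compound 1 to compound 2 (beyond the scatter) appears with a chain carbon in the link and has no counterpart when the ring sits directly on the nitrogen.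

These four compounds leave open how a phenethyl group, or a small acetyl or methyl group with no aromatic ring at all, would fare on the same ring nitrogen. A reading at one concentration also leaves open whether compound 3 and compound 4 would stay this close across a range of concentrations, and nothing available here gives a measured reason for these differences.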